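Fluoro-to-hydrogen step in the benzylamide of two cores

A few compounds are considered here, and "the series" means these few. Any claim that something is new, unique, unknown or untested is made for them only; others in the source may bear on it.

The series rests on two cores. Compound 1 `O=C(CC1c2ccccc2N=C(SCCCCCN2CCCC2)N1c1ccc(-c2ccccc2)cc1)NCc1ccc(F)cc1` and compound 3 `O=C(CC1c2ccccc2N=C(SCCCCCN2CCCC2)N1c1ccc(-c2ccccc2)cc1)NCc1ccccc1` share one core; compound 2 `CN(C)CCCCCSC1=Nc2ccccc2C(CC(=O)NCc2ccc(F)cc2)N1c1ccccc1` and the unmeasured compound 4 `CN(C)CCCCCSC1=Nc2ccccc2C(CC(=O)NCc2ccccc2)N1c1ccccc1` share the other. How the two cores differ is not broken down here.

In an assay on cells for inhibition of Voltage-dependent T-type calcium channel subunit alpha-1I (Homo sapiens), read by patch clamp (on this read-out lower numbers stand for stronger inhibition and higher numbers for weaker inhibition), compound 1 gives 13600 nM and compound 3 gives 810 nM. The change between them is hydrogen in place of fluoro on an aromatic carbon, and it made a step of a 17-fold lower number from compound 1 to compound 3 (1.23 log units; beyond the scatter). Compound 2 in this assay is reported as "not active" (no number reported), without a number.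

The change from compound 2 to compound 4 is hydrogen in place of fluoro on an aromatic carbon. Going by the values given here, the two place descriptions read the same word for word, so it is the same change as the one from compound 1 to compound 3, carried onto the second core. Among the compounds with values here, only one measured instance of the change exists, and the second core has no number to anchor it, so what can be expected for compound 4 is loosely bounded: the direction of a 17-fold lower number from compound 1 to compound 3 (1.23 log units; beyond the scatter) argues for a lower number than whatever compound 2 would have given, while the absence of a number for compound 2 leaves a real chance that compound 4 also comes back without one.

On that basis compound 4 is expected in this assay to give about 8000 nM, estimated between 1500 nM and 40000 nM.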

Compound 4, half-maximal inhibitory concentration: 3200 nM
The estimate for compound 4 lay 2.5-fold (0.40 log units) above the measured number, and the stated range covers the measured number.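

In this assay, going by these compounds alone, compound 4 gives 3200 nM, while compound 2 is reported as "not active" (no number reported), so no step between compound 2 and compound 4 can be read. The compounds shown leave open whether the fluoro-to-hydrogen change on this core is of a size comparable to a 17-fold lower number from compound 1 to compound 3 (1.23 log units; beyond the scatter). Nothing shown here offers an explanation for the result.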